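Ester aryl substituents on a shared core: antiproliferative read-out

A few compounds are considered here, and "the series" means these few. Any claim that something is new, unique, unknown or untested is made for them only; others in the source may bear on it.

Three compounds were measured in a functional assay on HCT-15 cells (Homo sapiens) for antiproliferative activity, read by sulforhodamine B assay, with a stated time of 48 h, tested at 50 uM; on this read-out lower numbers stand for less inhibition and higher numbers for more inhibition at the one concentration tested (going by the name of the read-out):

Compound 1 `CC1=CC[C@H](C(C)C)c2cc(C)c(OC(=O)c3ccc(C(F)(F)F)cc3)cc21` gave 6.4%
Compound 2 `CC1=CC[C@H](C(C)C)c2cc(C)c(OC(=O)c3ccc(Cl)cc3)cc21` gave 47.4%
Compound 3 `CC1=CC[C@H](C(C)C)c2cc(C)c(OC(=O)c3cccc(Cl)c3)cc21` gave 5.3%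

Compound 1 differs from compound 2 by trifluoromethyl in place of chloro on an aromatic carbon; in this assay this made a step of a number 41 percentage points lower from compound 2 to compound 1 (beyond the scatter). Compound 3 differs from compound 2 by 3-chlorophenyl in place of 4-chlorophenyl on a carbonyl carbon, a step of a number 42.1 percentage points lower from compound 2 to compound 3 (beyond the scatter). The gap between compound 3 and compound 1 lies within the scatter.

Compound 4 `CC1=CC[C@H](C(C)C)c2cc(C)c(OC(=O)c3cccc(C(F)(F)F)c3)cc21` has not been measured. It differs from compound 3 by trifluoromethyl in place of chloro on an aromatic carbon. This is the same kind of change as that from compound 2 to compound 1, not the same one: there the entering group sat para to a large group, here it sits meta to a large group.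

Little room is expected for a further fall, because compound 3 already gives 5.3% near the bottom of the read-out, so the step is estimated at a number 0.3 percentage points lower from compound 3 to compound 4 (within the scatter), far smaller than the earlier one. Compound 4 is expected to give 5%, between 0% and 20%.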

Compound 4, a percentage reported as inhibition, at one concentration (the size of the read-out at that concentration, not a potency): 15%
Compound 4: middle estimate off by 10 percentage points, on the low side, within the range that was stated.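

In this assay, trifluoromethyl in place of chloro made a step of a number 9.7 percentage points higher from compound 3 to compound 4 (within the scatter), so the earlier result of this change did not carry over: the same change on two cores in this assay, a number 41 percentage points lower (beyond the scatter) from compound 2 to compound 1 and a number 9.7 percentage points higher (within the scatter) from compound 3 to compound 4, 50.7 percentage points apart, beyond the scatter of two such steps

This change therefore cannot be carried from one core to another in this series as a fixed step, since its outcome here depended on the compound it started from. Going by these compounds alone, with only two pairs, the data do not show what separates them, nor how the change would behave on any further core.

The compounds shown carry only chloro or trifluoromethyl on the aromatic ring of the ester, so the effect of an amine or a carboxylic acid there remains open. From the compounds shown here alone, whether an amide could replace the ester link also remains open.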